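Aryl swap at the saturated ring carbon: compound 4

This account rests on a few compounds, and the source may have more. Where it says the series, first, only, none or still open, it means among the compounds named here.

Among the measured compounds shown here, compound 1 `CC(=O)N1N=C(c2ccc3ccccc3c2)OC1c1ccccc1Br` gives 5.49 ug/mL in a functional assay on MCF7 cells (Homo sapiens) for antiproliferative activity, read by MTT assay, with a stated time of 48 h (a lower number here means a stronger inhibitor, a higher number a weaker inhibitor), the second highest of the three numbers so far. Compound 2 `CC(=O)N1N=C(c2ccc3ccccc3c2)OC1c1ccccc1Cl` gives 2.36 ug/mL, and compound 3 `CC(=O)N1N=C(c2ccc3ccccc3c2)OC1c1ccc([N+](=O)[O-])cc1` gives 7.59 ug/mL. The halogen exchange gave a 2.3-fold lower number from compound 1 to compound 2 (0.37 log units; beyond the scatter). Compound 4 `CC(=O)N1N=C(c2ccc3ccccc3c2)OC1c1ccsc1` carries the change (thiophen-3-yl in place of 2-bromophenyl on a saturated ring carbon). For the measured compounds named here, the steps that bear on it are the earlier aryl replacements on the same saturated ring carbon: a 1.4-fold higher number from compound 1 to compound 3 (0.14 log units; within the scatter) and a 3.2-fold higher number from compound 2 to compound 3 (0.51 log units; beyond the scatter). Both are modest at most, so a step of that size or smaller is expected, with no direction fixed by the data, since nothing measured here holds a five-membered ring at that position. For compound 4 the expected value is 5.5 ug/mL, within 2.5 ug/mL to 12 ug/mL, which amounts to an expected 1.0-fold higher number from compound 1 to compound 4 (0.00 log units; within the scatter).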

Compound 4, half-maximal inhibitory concentration: 7.98 ug/mL
Beside the measured number, compound 4's estimate is 1.5-fold (0.16 log units) below it, and the stated range covers the measured number.
By their numbers in this assay, from the lowest: compound 2; then compounds 1, 3 and 4 (each within the scatter of the next).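

A five-membered aromatic ring with one hetero atom fits at this saturated ring carbon without a readable shift from the six-membered aryl groups of compound 1 and compound 3: a 1.5-fold higher number from compound 1 to compound 4 (0.16 log units; within the scatter) and a 1.1-fold higher number from compound 3 to compound 4 (0.02 log units; within the scatter). Only the 2-chlorophenyl group stays apart from the thiophen-3-yl group, with a 3.4-fold higher number from compound 2 to compound 4 (0.53 log units; beyond the scatter). No evidence explains this result.

Still open, as far as these compounds go, is whether an aminomethyl or a carboxylic acid on the aromatic ring at this carbon would move the number. From the compounds shown here alone, the effect of thiophen-2-yl or furan-3-yl at the same place is also open.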